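Permeability estimated from a single measured neighbour

The compounds below may be only part of what the source reports. "The series", "measured", "known", "first", "only" and "open" are said of these compounds alone.

For the measured compounds named here, in a physicochemical assay for permeability, using PAMPA (a higher number here means that the compound crosses the layer faster, a lower number that the compound crosses the layer more slowly), compound 2 `Cc1oc(-c2ccc(Cl)c(Cl)c2)nc1CN1CCC(C(=O)NCCCN2C[C@H](C)C[C@H](C)C2)CC1` gives 522 10^-6 cm/s, the only number available in this small set. Compound 1 `Cc1cc(C)c(-c2nc(CN3CCC(C(=O)NCCCN4C[C@H](C)C[C@H](C)C4)CC3)c(C)o2)c(C)c1` is recorded as "not determined" (no result reported). Compound 3 `Cc1cccc(Cl)c1-c1nc(CN2CCC(C(=O)NCCCN3CCC(C)(C)CC3)CC2)c(C)o1` is likewise recorded as "not determined" (no result reported). Compound 4 `Cc1cccc(-c2nc(CN3CCC(C(=O)NCCCN4C[C@H](C)C[C@H](C)C4)CC3)c(C)o2)c1` is still unmeasured, and it carries 3-methylphenyl in place of 3,4-dichlorophenyl on an aromatic carbon. Going by the values given here, no measured pair shows what such a swap does, which leaves compound 2 at 522 10^-6 cm/s as the sole anchor. No step beyond the usual scatter is expected in this assay. The estimated change is a 1.2-fold lower number from compound 2 to compound 4 (0.08 log units; within the scatter). For compound 4, the expected value is 430 10^-6 cm/s, with an estimated range of 170 10^-6 cm/s to 950 10^-6 cm/s.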

Compound 4, apparent permeability: 279 10^-6 cm/s
For compound 4 the middle estimate is 1.5-fold (0.19 log units) above the measured one, and the stated range covers the measured number.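

In this assay, for the compounds shown here, putting 3-methylphenyl in place of 3,4-dichlorophenyl on this aromatic carbon gives a 1.9-fold lower number from compound 2 to compound 4 (0.27 log units; within the scatter), the first direct reading of any change at this position. For this one pair, the difference cannot be told apart from the ordinary spread of repeated measurements. Nothing available explains the step at the level of structure. One pair says little about the position as a whole. As far as these compounds go, whether a carboxylic acid or an amine on this phenyl ring would take the number beyond the scatter remains open.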